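The source may report more compounds than this note shows. Statements on the series, on what has been measured and on what is new or still open speak of the compounds shown alone.

Compound 2 `C=CC(=O)Nc1cc(Nc2ncc(Cl)c(Nc3ccccc3S(=O)(=O)C(C)C)n2)c(OC)cc1N1CCCN(C)CC1` stands at the strong end of what has been measured. In a functional assay on NCI-H3122 cells (Homo sapiens) for inhibition, read by CellTiter-Glo, with a stated time of 72 h (a lower number here means a stronger inhibitor of growth, a higher number a weaker inhibitor of growth), compound 2 reaches only a limit, < 0.3 nM, so its exact value is not known. Compound 1 `C=CC(=O)Nc1cc(Nc2ncc(Cl)c(Nc3ccccc3S(=O)(=O)C(C)C)n2)c(OC)cc1N1CCN(C)CC1` gives 33 nM in this assay, and the step of an at least 110-fold lower number from compound 1 to compound 2 (2.04 log units; beyond the scatter) shows how sharply this position answers to the group placed on it. Compound 2 sits at the limit of < 0.3 nM in this assay, at which 1 of the 2 values shown sits. Compound 3 `C=CC(=O)Nc1cc(Nc2ncc(Cl)c(Nc3ccccc3S(=O)(=O)C(C)C)n2)c(OC)cc1N1CCN(C2CCCCC2)CC1` carries 4-cyclohexylpiperazin-1-yl in place of 4-methyl-1,4-diazepan-1-yl on an aromatic carbon. Among the measured compounds shown here, only that one measured step bears on the change; the new group returns to a six-membered ring with two hetero atoms while adding a cyclohexyl, and the direction is uncertain. Compound 3 is expected to fall between the two measured results, estimated at 3 nM with a range from 0.3 nM to 30 nM, a step of an at least 10-fold higher number from compound 2 to compound 3 (1.00 log units; beyond the scatter).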

Compound 3, concentration for 50% growth inhibition: < 0.3 nM
Compound 3: a limit, no number; the forecaster's own chance of this, stated with the estimate: 20%; middle value at least 10-fold (1.00 log units) from the limit.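

In this assay compound 3 reaches only a limit, < 0.3 nM. Among the compounds shown here, with the piperazine ring kept, cyclohexyl in place of methyl gives an at least 110-fold lower number from compound 1 to compound 3 (2.04 log units; beyond the scatter), so at this position the seven-membered ring of compound 2 is not the only change that reaches the limit. The step between compound 2 and compound 3 cannot be read, and both now rest at the same limit: the limit of < 0.3 nM in this assay, at which 2 of the 3 values shown sit.

On these data alone, how compound 2 and compound 3 rank remains open. So does whether an ethyl or a tetrahydropyran-4-yl group on that piperazine nitrogen would also reach the limit.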